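A Z-configured cinnamate ester in the cytotoxicity series

The compounds below may be only part of what the source reports. "The series", "measured", "known", "first", "only" and "open" are said of these compounds alone.

This account concerns a pair of ester derivatives sharing one diterpenoid alcohol core. Compound 1 `C=CC(=C)CC[C@@H]1[C@@]2(C)CCC[C@](C)(COC(=O)/C=C/c3ccc(O)cc3)[C@@H]2CC[C@@]1(C)O` in a functional assay on SMMC-7721 cells (Homo sapiens) for cytotoxicity, read by MTT assay, with a stated time of 48 h (a higher number here means a weaker inhibitor, a lower number a stronger inhibitor), gives 15500 nM. Compound 2 `C=CC(=C)CC[C@@H]1[C@@]2(C)CCC[C@](C)(COC(=O)/C=C/c3ccc(O)c(OC)c3)[C@@H]2CC[C@@]1(C)O` in this assay gives 14100 nM. Among the measured compounds shown here, the single change between them, a methoxy in place of hydrogen on an aromatic carbon, yields a 1.1-fold lower number from compound 1 to compound 2 (0.04 log units; within the scatter). Compound 2 and compound 1 therefore stand within the scatter of each other, and neither can be called the stronger inhibitor.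

The next compound, compound 3 `C=CC(=C)CC[C@@H]1[C@@]2(C)CCC[C@](C)(COC(=O)/C=C\c3ccc(O)c(OC)c3)[C@@H]2CC[C@@]1(C)O`, keeps every atom and bond of compound 2; (the two compounds have the same atoms and bonds and differ only in configuration as drawn: 1 of 6 stereo elements differ; a double bond is drawn E in compound 2 and Z in compound 3). For the measured compounds named here, no measured step in this set concerns the geometry of the double bond: the only step known changes a substituent on the aromatic ring and does not bear on a change of configuration. With nothing in the data to indicate a direction, the expectation for this assay is a step of no more than the scatter, a 1.1-fold higher number from compound 2 to compound 3 (0.05 log units; within the scatter). Compound 3 is thus estimated in this assay at 16000 nM, within a range of 6000 nM to 45000 nM.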

Compound 3, half-maximal inhibitory concentration: 7500 nM
Compound 3: the middle estimate sits 2.1-fold (0.33 log units) above what was measured; the measured number falls inside the stated range.
By their numbers in this assay, from the lowest: compounds 3, 2 and 1 (each within the scatter of the next, the first and the last beyond it).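

Compound 3 brings the geometry of the ester double bond into the series as a change of its own, and in this assay that change gives a 1.9-fold lower number from compound 2 to compound 3 (0.27 log units; within the scatter), so this single pair does not separate the E and Z forms. The wider step, a 2.1-fold lower number from compound 1 to compound 3 (0.32 log units; beyond the scatter), is the only one in the set that passes the scatter; it is modest and carries the methoxy and the Z geometry together, while each of those two changes, read alone, stays within the scatter. Any reading of the pair as a test of geometry alone rests on how closely the two structures match: the fact that compounds 2 and 3 differ only in the configuration as drawn

The compounds shown leave open whether the Z double bond would give a similar step on the ester without the methoxy, since no Z counterpart of compound 1 stands among them. They also leave open how the series would respond to an amine or a carboxylic acid on the aromatic ring, or to an amide in place of the ester.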